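Moving a methyl from the chain to the nitrogen

The compounds below may be only part of what the source reports. "The series", "measured", "known", "first", "only" and "open" are said of these compounds alone.

Measured compounds:
- compound 1, `CNc1cccc(-c2cc(=O)c3cc(N4CCCC4)ccc3[nH]2)c1`, 6 nM
- compound 2, `CCNc1cccc(-c2cc(=O)c3cc(N4CCCC4)ccc3[nH]2)c1`, 5 nM

Of the compounds shown here, two sharing one core have been tested in a functional assay on HL-60 cells (Homo sapiens) for cytotoxicity; on this read-out higher numbers stand for weaker inhibition and lower numbers for stronger inhibition. Compound 1 carries a methylamino group on its outer ring and gives 6 nM. Compound 2 carries an ethylamino group in the same place and gives 5 nM. The step of a 1.2-fold lower number from compound 1 to compound 2 (0.08 log units; within the scatter) adds one methyl to the saturated carbon bound to the ring nitrogen. Compound 2 holds the lowest of the two numbers, but its gap to compound 1 is within the scatter, so the two cannot be ordered.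

Compound 3, `CN(C)c1cccc(-c2cc(=O)c3cc(N4CCCC4)ccc3[nH]2)c1`, has the same atoms joined differently: dimethylamino in place of ethylamino on an aromatic carbon. Within the data shown here, the only measured step, from compound 1 to compound 2, touched the same group and stayed within the scatter. Among the measured compounds shown here, no measured step removes the hydrogen-bond donor, so that part of the change is untested. On this footing compound 3 is expected to stay close to compound 2, with a step of a 1.4-fold higher number from compound 2 to compound 3 (0.15 log units; within the scatter) in this assay. The estimate for compound 3 is 7 nM, within 2.5 nM to 20 nM.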

Compound 3, half-maximal inhibitory concentration: 5 nM
The estimate for compound 3 lay 1.4-fold (0.15 log units) above the measured number; the range from low to high includes it.
By their numbers in this assay, from the lowest: compounds 2, 3 and 1 (each within the scatter of the next).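

In this assay, swapping ethylamino for dimethylamino on the aromatic carbon gives no change at the digits printed from compound 2 to compound 3 (within the scatter), even though the swap takes away the hydrogen-bond donor that this group has in compound 1 and compound 2. Adding a methyl to the nitrogen of the methylamino group gives a 1.2-fold lower number from compound 1 to compound 3 (0.08 log units; within the scatter), so in these three compounds the second carbon can sit on the chain or on the nitrogen without moving the number beyond the scatter, and the hydrogen on that nitrogen is not needed for a value in this range. Nothing available here explains why the three compounds stay so close.

On these data alone, all three groups are small and carry an amine nitrogen with no more than two carbons attached, so it remains open how far this tolerance extends, for example to a plain amino group, a longer chain such as butylamino, or a carboxylic acid in the same place. As far as these compounds go, it is also open whether the same tolerance would hold on a different core or in a different cell line.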